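Swapping a Phenyl for Piperidinyl on a Sulfonamide Core

The source may hold more compounds than are shown below. What is called first, only, known or untested is meant among the compounds shown, and "the series" means these compounds.

This piece follows three sulfonamide compounds tested in an ADME assay on HCT-116 cells (Homo sapiens) for cytotoxicity, read by CellTiter-Glo, with a stated time of 72 h (on this read-out lower numbers stand for stronger inhibition and higher numbers for weaker inhibition), and asks what a fourth, untested one might do. Compound 1 has the structure `Cc1cc(C)c(S(=O)(=O)N2CCC(c3ccccc3)CC2)c(C)c1`. In this assay compound 1 reaches only a limit, > 5000 nM. Compound 2, `CC1CCN(C2CCN(S(=O)(=O)c3cccc(-c4ccc(F)cc4)c3)CC2)CC1`, likewise stops at a limit, giving > 5000 nM. Compound 3, `COc1ccc(-c2ccccc2S(=O)(=O)N2CCC(N3CCC(C)CC3)CC2)cc1`, also sits at a limit with > 5000 nM. Going by the values given here, none of the three carries a true number, so none can be placed above or below another, and compound 1 stands simply alongside the other two; the only evidence available is the limit of > 5000 nM in this assay, at which 3 of the 3 values shown sit.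

The untested compound 4 is `Cc1cc(C)c(S(=O)(=O)N2CCC(N3CCCCC3)CC2)c(C)c1`. It differs from compound 1 in a single place: piperidin-1-yl in place of phenyl on a saturated ring carbon. Among the compounds with values here, no step between measured compounds exists to calibrate this change, and every measured compound rests at a limit, so the step is expected to be a step that the limit leaves unreadable from compound 1 to compound 4, nothing the assay would resolve beyond its usual scatter. Compound 4 is therefore expected to return 10000 nM, with a likely range from 5000 nM to 30000 nM, and most probably this assay will again report only a limit rather than a number.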

Compound 4, half-maximal inhibitory concentration: > 5000 nM
Compound 4: only a limit was reported; the forecaster's own chance of this, stated with the estimate: 85%; the middle value is on the limit's open side.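

Compound 4 gives only a limit in this assay, > 5000 nM. Going by these compounds alone, compound 1 also gives only a limit, so no step from compound 1 to compound 4 can be read. Whether any of these compounds has a true value here, and how piperidin-1-yl compares with phenyl, stays open: the limit of > 5000 nM in this assay, at which 4 of the 4 values shown sit.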